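From Diethylamino to Imidazolyl: What Compound 4 Might Show

This account rests on a few compounds, and the source may have more. Where it says the series, first, only, none or still open, it means among the compounds named here.

Compound 1 `COc1ccc(C(=O)/C=C/c2ccc(Br)cc2)c2c1C=CC(C)(C)O2` carries a bromo group. In a functional assay on HCT-116 cells (Homo sapiens) for antiproliferative activity, read by MTT assay, with a stated time of 24 h (on this read-out higher numbers stand for weaker inhibition and lower numbers for stronger inhibition), compound 1 gives only a limit, > 10000 nM (the limit of > 10000 nM in this assay, at which 1 of the 3 values shown sits). Compound 2 `COc1ccc(C(=O)/C=C/c2ccc(N(C)C)cc2)c2c1C=CC(C)(C)O2` replaces that bromo with dimethylamino and gives 1920 nM. Compound 3 `CCN(CC)c1ccc(/C=C/C(=O)c2ccc(OC)c3c2OC(C)(C)C=C3)cc1` carries diethylamino instead and gives 620 nM, the lowest of the two numbers shown. The steps are an at least 5.2-fold lower number from compound 1 to compound 2 (0.71 log units; beyond the scatter), an at least 16-fold lower number from compound 1 to compound 3 (1.20 log units; beyond the scatter) and a 3.1-fold lower number from compound 2 to compound 3 (0.49 log units; beyond the scatter).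

Compound 4 `COc1ccc(C(=O)/C=C/c2ccc(-n3ccnc3)cc2)c2c1C=CC(C)(C)O2` differs from compound 3 in one place: 1H-imidazol-1-yl in place of diethylamino on an aromatic carbon. For the measured compounds named here, no measured step involves an imidazolyl group, so the measured steps bear on it only indirectly: they show that the diethylamino of compound 3 stands far from the bromo of compound 1 an at least 16-fold lower number from compound 1 to compound 3 (1.20 log units; beyond the scatter), and compound 4 loses that diethylamino. Compound 4 is therefore expected to give a higher number, about 5000 nM (from 1200 nM to 20000 nM), an estimated step of an 8.1-fold higher number from compound 3 to compound 4 (0.91 log units; beyond the scatter).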

Compound 4, half-maximal inhibitory concentration: > 10000 nM
Compound 4: no number, only a limit; the forecaster's own chance of this, stated with the estimate: 35%; middle value at least 2.0-fold (0.30 log units) away from the limit.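

At this place on the aromatic ring, a group with as many heavy atoms as diethylamino does not keep the activity: in this assay, 1H-imidazol-1-yl in place of diethylamino gives an at least 16-fold higher number from compound 3 to compound 4 (1.20 log units; beyond the scatter). The same group in place of dimethylamino gives an at least 5.2-fold higher number from compound 2 to compound 4 (0.71 log units; beyond the scatter), so both amino compounds stand apart from compound 4. Compound 4 gives only a limit, as does compound 1, and the step between these two cannot be read: the limit of > 10000 nM in this assay, at which 2 of the 4 values shown sit.

The compounds shown leave open whether the ring itself or the type of nitrogen matters. A pyrrolidine ring or a longer dipropylamino chain at this place could help separate the two.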